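This account rests on a few compounds, and the source may have more. Where it says the series, first, only, none or still open, it means among the compounds named here.

Compound 1 `CCNC(=O)c1oc2nc(-c3ccccc3)cc(C(F)(F)F)c2c1N` gives 70000 nM in an ADME assay on HEK293 cells (Homo sapiens) for antiproliferative activity, read by MTT assay; on this read-out higher numbers stand for weaker inhibition and lower numbers for stronger inhibition.
Compound 2 `Nc1c(C(=O)N/N=C/c2ccccc2)oc2nc(-c3ccccc3)cc(C(F)(F)F)c12` gives 70000 nM in this assay.
Compound 3 `Nc1c(C(=O)N/N=C/c2ccc(Br)cc2)oc2nc(-c3cccs3)cc(C(F)(F)F)c12` gives 86000 nM in this assay.

The three numbers sit close together. Compound 3 gives the largest of them, yet its gap to compound 1 and its gap to compound 2 both lie within the scatter, so the three compounds cannot be told apart on this assay.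

Compound 4 `Nc1c(C(=O)N/N=C/c2ccc(Br)cc2)oc2nc(-c3ccccc3)cc(C(F)(F)F)c12` differs from compound 3 in one place: phenyl in place of thiophen-2-yl on an aromatic carbon. Among the measured compounds shown here, no measured step concerns this part of the shared core. For the measured compounds named here, the only measured step is no change at the digits printed from compound 1 to compound 2 (within the scatter), which concerns the amide-type nitrogen and showed no change. Compound 1 and compound 3 differ at both the amide-type nitrogen and this aromatic carbon, and their numbers still lie within the scatter of each other, which gives no hint of a large effect from either change. Compound 4 is therefore expected to give a number close to that of compound 3, with a 1.1-fold lower number from compound 3 to compound 4 (0.03 log units; within the scatter) as the expected step. The estimate for compound 4 in this assay is 80000 nM, within a range from 40000 nM to 160000 nM.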

Compound 4, half-maximal inhibitory concentration: 64000 nM
The estimate for compound 4 lay 1.3-fold (0.10 log units) above the measured number; the measured number falls inside the stated range.
By their numbers in this assay, from the lowest: compounds 4, 1, 2 and 3 (each within the scatter of the next).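

Among the compounds shown here, the first measured step at this position, phenyl in place of thiophen-2-yl on the aromatic carbon next to the ring nitrogen, stays within the scatter in this assay (a 1.3-fold lower number from compound 3 to compound 4 (0.13 log units; within the scatter)). Bromo in place of hydrogen on an aromatic carbon also stays within the scatter (a 1.1-fold lower number from compound 2 to compound 4 (0.04 log units; within the scatter)), as does the change of group on the amide-type nitrogen (a 1.1-fold lower number from compound 1 to compound 4 (0.04 log units; within the scatter)), so none of the three changes separates the compounds on this read-out. Nothing measured here bears on why these numbers sit so close together.

The compounds shown leave open whether an amine or a carboxylic acid on this aromatic carbon would move the number beyond the scatter. They also leave open whether a methoxy group in place of the bromo would do so.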